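Swapping the aryl cap on compound 1's piperazine

The source may report more compounds than this note shows. Statements on the series, on what has been measured and on what is new or still open speak of the compounds shown alone.

Measured so far in a functional assay on A-375 cells (Homo sapiens) for antiproliferative activity, read by CCK-8 assay, with a stated time of 72 h, tested at 8 uM; a higher number here means a stronger effect of the compound at the concentration tested, a lower number a weaker effect:
- compound 1 `Nc1ccccc1NC(=O)c1ccc(CSC(=S)N2CCN(c3ccc(Cl)cc3)CC2)cc1`: 29%
- compound 2 `CC1CCN(C(=S)SCc2ccc(C(=O)Nc3ccccc3N)cc2)CC1`: 87.4%
- compound 3 `CN(Cc1cccnc1)C(=S)SCc1ccc(C(=O)Nc2ccccc2N)cc1`: 83.8%

Compound 1 stands lowest of the three, well beyond the scatter below both compound 2 and compound 3. Compound 4 `Nc1ccccc1NC(=O)c1ccc(CSC(=S)N2CCN(c3cnccn3)CC2)cc1` is not yet measured; it differs from compound 1 by pyrazin-2-yl in place of 4-chlorophenyl on an amine nitrogen in a ring. Among the measured compounds shown here, the only measured step, a number 3.6 percentage points lower from compound 2 to compound 3 (within the scatter), swaps the whole amine on the thiocarbonyl carbon and lies within the scatter, so it does not address a change of the aryl cap on the ring nitrogen. No shown step therefore bears on this change, and the direction is uncertain. Compound 4 is expected to give 45%, within 20% to 75%, an expected step of a number 16 percentage points higher from compound 1 to compound 4 (beyond the scatter).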

Compound 4, a percentage reported as inhibition, at one concentration (the size of the read-out at that concentration, not a potency): 85.8%
Compound 4: the middle estimate sits 40.8 percentage points below what was measured; the whole stated range lies below it.
By their numbers in this assay, from the lowest: compound 1; then compounds 3, 4 and 2 (each within the scatter of the next).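

In this assay, pyrazin-2-yl in place of 4-chlorophenyl on an amine nitrogen in a ring gives a number 56.8 percentage points higher from compound 1 to compound 4 (beyond the scatter), so the low number of compound 1 depends on this cap and not on the shared core alone. The change removes chlorine and brings in two ring nitrogens, and this single pair cannot show which of these matters. Nothing measured here explains the step. On these data alone, it remains open whether plain phenyl, with neither chlorine nor ring nitrogen, would read like compound 1 or like compound 4. The same question holds for pyridin-2-yl, which has one ring nitrogen.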